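From dimethylamino to methyl: does a number return?

The compounds below may be only part of what the source reports. "The series", "measured", "known", "first", "only" and "open" are said of these compounds alone.

Compound 3 `CN(C)c1ncnc2c1c(-c1ccoc1)cn2[C@@H]1O[C@H](CO)[C@@H](O)[C@H]1O` reads > 20000 nM in a functional assay on HCT-116 cells (Homo sapiens), read by MTT assay, with a stated time of 72 h (on this read-out higher numbers stand for weaker inhibition and lower numbers for stronger inhibition), and that is a limit, not a number. Compound 2 `CNc1ncnc2c1c(-c1ccoc1)cn2[C@@H]1O[C@H](CO)[C@@H](O)[C@H]1O` reads > 20000 nM as the same kind of limit. Compound 1 `CSc1ncnc2c1c(-c1ccoc1)cn2[C@@H]1O[C@H](CO)[C@@H](O)[C@H]1O` alone gives a true number, with 40 nM as its reading. Methylamino and dimethylamino in place of methylsulfanyl gave an at least 500-fold higher number from compound 1 to compound 2 (2.69 log units; beyond the scatter) and an at least 500-fold higher number from compound 1 to compound 3 (2.69 log units; beyond the scatter) as two large steps. Compound 4 `Cc1ncnc2c1c(-c1ccoc1)cn2[C@@H]1O[C@H](CO)[C@@H](O)[C@H]1O` has methyl in place of dimethylamino on an aromatic carbon and so, like compound 1, carries no nitrogen on that carbon. Those two steps are the closest guide, so a large step is expected, with an at least 100-fold lower number from compound 3 to compound 4 (2.00 log units; beyond the scatter) as the estimate, towards stronger inhibition. Compound 4 is estimated at 200 nM within 30 nM to 3000 nM as its expected range.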

Compound 4, half-maximal inhibitory concentration: > 20000 nM
Compound 4 ended at the assay's limit; the forecaster's own chance of this, stated with the estimate: 10%; at least 100-fold (2.00 log units) between middle value and limit.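

In this assay, having no nitrogen on this aromatic carbon is not enough for activity: methyl carries none, yet the change gives an at least 500-fold higher number from compound 1 to compound 4 (2.69 log units; beyond the scatter). Among the groups shown at this position, only methylsulfanyl gives a true number. Compounds 2, 3 and 4 each give a limit rather than a number, so the steps among them cannot be read: the limit of > 20000 nM in this assay, at which 3 of the 4 values shown sit.

From the compounds shown here alone, whether the sulfur or the methyl of methylsulfanyl matters more stays open. So does whether methoxy or ethylsulfanyl on this carbon would return a true number.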